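The compounds below may be only part of what the source reports. "The series", "measured", "known", "first", "only" and "open" are said of these compounds alone.

Measured compounds:
compound 1 `O=C(c1ccc2cc(OCCCN3CCCCC3)ccc2c1)N1CCC(CO)CC1`, which in a physicochemical assay for acid dissociation, gives 9.6;
compound 2 `O=C(c1ccc2cc(OCCCN3CCCCC3)ccc2n1)N1CCC1`, which in this assay gives 9.4;
compound 3 `CC1CCN(C(=O)c2ccc3cc(OC4CCN(C(C)C)CC4)ccc3c2)CC1`, which in this assay gives 9.6.

Compound 2 holds the lowest of the three numbers, yet both compound 1 and compound 3 lie within the usual scatter of it, so the three cannot be set in order. Compound 4 `CC1CCN(C(=O)c2ccc3cc(OCCCN4CCCCC4)ccc3n2)CC1` has not yet been measured. It differs from compound 2 in one place: 4-methylpiperidin-1-yl in place of azetidin-1-yl on a carbonyl carbon. For the measured compounds named here, no measured pair shows this change on its own, so its size cannot be read from the data. Since all three measured values sit together, the step from compound 2 to compound 4 is expected to be none beyond the scatter, a number 0.10 log units higher from compound 2 to compound 4 (within the scatter). For compound 4 the estimate is 9.5, between 9.2 and 9.8.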

Compound 4, acid dissociation constant: 9.7
Compound 4: the middle estimate sits 0.20 log units below what was measured; low and high end bracket the measured number.
By their numbers in this assay, from the lowest: compounds 2, 1, 3 and 4 (each within the scatter of the next).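

For the compounds shown here, putting 4-methylpiperidin-1-yl in place of azetidin-1-yl on a carbonyl carbon, a change no earlier pair showed on its own, gives a number 0.30 log units higher from compound 2 to compound 4 (within the scatter) in this assay. At this position, then, going from a four-membered to a six-membered non-aromatic ring does not move the reading beyond the scatter. Nothing available accounts for this result.

Still open, from the compounds shown here alone, is whether a group on this carbonyl that carries a primary amine or a carboxylic acid would shift the number beyond the scatter. Also open, going by these compounds, is whether the same change would behave alike on the core of compound 1.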